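The source may hold more compounds than are shown below. What is called first, only, known or untested is meant among the compounds shown, and "the series" means these compounds.

Of the compounds shown here, three from this study have so far been tested in a functional assay on MCF7 cells (Homo sapiens) for antiproliferative activity, read by MTT assay, with a stated time of 72 h; a lower number here means a stronger inhibitor, a higher number a weaker inhibitor. Compound 1 `O=C1COc2ccc(-c3cccc(NS(=O)(=O)c4ccc(F)cc4)c3)cc2N1C1CC1` reaches only the limit of the assay, giving > 40000 nM. Compound 3 `O=C1COc2ccc(-c3cnc(Cl)c(NS(=O)(=O)c4ccc(F)cc4)c3)cc2N1c1ccccc1` likewise stops at the limit, with > 40000 nM. Compound 2 `COc1ccc(N2C(=O)COc3ccc(-c4cnc5ccccc5c4)cc32)cc1` stands at the same limit in this assay, with > 40000 nM, so for it only a boundary and no number is known. Within the data shown here, all three results share (the limit of > 40000 nM in this assay, at which 3 of the 3 values shown sit), which leaves no measured step between compounds to lean on.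

Compound 4 `O=C1COc2ccc(-c3cnc4ccccc4c3)cc2N1c1ccccc1` has not yet been measured. It differs from compound 2 in one place: hydrogen in place of methoxy on an aromatic carbon. Among the measured compounds shown here, nothing among the measured values shows how this change moves the number in this assay, and every comparison point sits at the limit. The step in this assay is therefore expected to be a step that the limit leaves unreadable from compound 2 to compound 4, nothing beyond the scatter. Compound 4 is estimated at 50000 nM in this assay, within a range from 20000 nM to 150000 nM, and most likely again only a limit will be reported.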

Compound 4, half-maximal inhibitory concentration: > 40000 nM
Compound 4 was reported as a limit (the forecaster's own chance of this, stated with the estimate: 80%); the middle value does not contradict the limit.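

Compound 2 and compound 4 both give only a limit and no number, so no step can be read for the change from 4-methoxyphenyl to phenyl: the limit of > 40000 nM in this assay, at which 4 of the 4 values shown sit.

The compounds shown leave open how 4-methoxyphenyl and phenyl truly compare, and which structural features would give a measurable value.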